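The compounds below may be only part of what the source reports. "The series", "measured", "known", "first", "only" and "open" are said of these compounds alone.

Series notes. Compound 1 `O=c1cc(-c2ccccc2)oc2cc(OC/C(=N/O)c3ccccc3)ccc12` gives 2000000 nM in a functional assay on SK-HEP1 cells (Homo sapiens) for antiproliferative activity; on this read-out higher numbers stand for weaker inhibition of growth and lower numbers for stronger inhibition of growth. Compound 2 `O=c1cc(-c2ccccc2)oc2cc(OC/C(=N/O)c3ccc(F)cc3)ccc12` gives 2300000 nM in this assay. The change between them is fluoro in place of hydrogen on an aromatic carbon and it made the step of a 1.2-fold higher number from compound 1 to compound 2 (0.06 log units; within the scatter). Compound 3 `O=c1c(-c2ccccc2)coc2cc(OC/C(=N/O)c3ccccc3)ccc12` carries a different core; how its core differs from that of compound 1 is not broken down here. Compound 3 gives 6400000 nM in this assay, the highest number of the three and beyond the scatter from both compound 1 and compound 2. Compound 4 `O=c1c(-c2ccccc2)coc2cc(OC/C(=N/O)c3ccc(F)cc3)ccc12` is not yet measured; it differs from compound 3 by fluoro in place of hydrogen on an aromatic carbon, the same change as from compound 1 to compound 2, at the same place. The earlier step of a 1.2-fold higher number from compound 1 to compound 2 (0.06 log units; within the scatter) lay within the scatter. On that basis the step expected for compound 4 in this assay is a 1.2-fold higher number from compound 3 to compound 4 (0.06 log units; within the scatter). Compound 4 is therefore estimated at 7400000 nM, between 3500000 nM and 15000000 nM.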

Compound 4, concentration for 50% growth inhibition: 6610000 nM
Beside the measured number, compound 4's estimate is 1.1-fold (0.05 log units) above it; the range from low to high includes it.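

In this assay, phenyl to 4-fluorophenyl on the core of compound 3 gives a 1.0-fold higher number from compound 3 to compound 4 (0.01 log units; within the scatter), so the step stays small on this core as well. Set beside the earlier step, the two agree: the same change on two cores in this assay, a 1.2-fold higher number (0.06 log units; within the scatter) from compound 1 to compound 2 and a 1.0-fold higher number (0.01 log units; within the scatter) from compound 3 to compound 4, 1.1-fold (0.05 log units) apart, within the scatter of two such steps. The fluoro change therefore carries across these two cores with no step beyond the scatter, but this shows only that it does little on both, not that a sizeable effect transfers, and it says nothing about other cores or other cell lines.

Open, going by these compounds, is whether a different group on the same aromatic carbon, such as an amine, a methoxy group or a carboxylic acid, would move the number beyond the scatter. Also open, on these data alone, is whether such a step would then be the same on both cores.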